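The compounds below may be only part of what the source reports. "The series", "measured", "known", "first", "only" and "open" are said of these compounds alone.

In a functional assay (strain AB) with Danio rerio as the target, read by microscopy, with a stated time of 1 h (a lower number here means that less compound is needed, a higher number that more compound is needed for the effect), three compounds have been tested, and only one of them gives a true number. Compound 1 `CCC1CCc2c(sc(NC(=O)Nc3ccc(Cl)cc3)c2C(N)=O)C1` reads > 25000 nM, which is a limit of the assay and not a number. Compound 3 `CCN1CCc2c(sc(NC(=O)C3(c4ccc(Cl)cc4)CC3)c2C(N)=O)C1` reads > 25000 nM, which is also a limit. Among the compounds with values here, compound 2 `C[N+]1(CC2CCCCC2)CCc2c(sc(NC(=O)Nc3ccc(Cl)cc3)c2C(N)=O)C1` gives 100 nM, the only number in the set, so it has no measured number to be ranked against.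

Compound 4 `C[N+]1(CC2CCCC2)CCc2c(sc(NC(=O)Nc3ccc(Cl)cc3)c2C(N)=O)C1` has not yet been measured. It matches compound 2 except for one group: cyclopentyl in place of cyclohexyl on a saturated chain carbon bound to an amine nitrogen in a ring. In words, cyclopentyl stands in place of cyclohexyl on a saturated chain carbon bound to an amine nitrogen in a ring.

Within the data shown here, no pair of measured compounds differs in just one place, so the data offer no direct guide to the size of this step. The group that enters is, like the one that leaves, a non-aromatic ring of carbon only. With compound 2 at 100 nM as the sole starting point, a small step is expected in this assay, towards a somewhat higher number and near the edge of the usual scatter. As a step, the estimate is a 2.0-fold higher number from compound 2 to compound 4 (0.30 log units; within the scatter). Compound 4 is expected at about 200 nM, with an estimated range of 60 nM to 800 nM.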

Compound 4, half-maximal effective concentration: 200 nM
The estimate for compound 4 equals the measured number at the digits printed, within the range that was stated.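

The swap of cyclohexyl for cyclopentyl, on a saturated chain carbon bound to an amine nitrogen in a ring, gives in this assay a 2.0-fold higher number from compound 2 to compound 4 (0.30 log units; within the scatter). Within the data shown here, this is the first step that can be read at this place, and it shows that the five-membered ring and the six-membered ring give values that cannot be told apart, so compound 4 joins compound 2 as a second compound with a true number. Among these compounds, compound 1 and compound 3 each stand at a limit and not at a number, so no step to either of them can be read: the limit of > 25000 nM in this assay, at which 2 of the 4 values shown sit.

The compounds shown carry only these two non-aromatic rings of carbon at this place, so it remains open whether a smaller ring such as cyclobutyl, a flat phenyl ring or an open chain such as hexyl would give a similar value. On these data alone, it also remains open what a hydroxyl group or an amine on the ring would do to the number in this assay.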